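Sulfonyl aryl swap on the methoxy-bearing core

The compounds below may be only part of what the source reports. "The series", "measured", "known", "first", "only" and "open" are said of these compounds alone.

Compound 2 `COc1ccc2ncc(S(=O)(=O)c3ccc(OC)c(Cl)c3)c(N3CCC(C)CC3)c2c1` stands lowest of the two compounds measured in an assay on isolated protein for displacement of a labelled ligand from metabotropic glutamate receptor 5 (Homo sapiens), with a stated time of 60 min, tested at 1 uM (on this read-out lower numbers stand for less inhibition and higher numbers for more inhibition at the one concentration tested (going by the name of the read-out)), giving 21%. Compound 1 `Cc1ccc(S(=O)(=O)c2cnc3ccc(Cl)cc3c2N2CCC(C)CC2)cc1F` gives 68% in this assay, a gap beyond the scatter, and it carries the same 3-fluoro-4-methylphenyl group on the sulfonyl sulfur that compound 3 `COc1ccc2ncc(S(=O)(=O)c3ccc(C)c(F)c3)c(N3CCC(C)CC3)c2c1` takes up. The change from compound 2 to compound 3: 3-fluoro-4-methylphenyl in place of 3-chloro-4-methoxyphenyl on a sulfonyl sulfur. Going by the values given here, since compound 1 reaches 68% with this group, an upward step a number 24 percentage points higher from compound 2 to compound 3 (beyond the scatter) is expected, though the two cores differ and no step across cores has been measured. Compound 3 is estimated at 45%, with a range of 20% to 70%.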

Compound 3, a percentage reported as inhibition, at one concentration (the size of the read-out at that concentration, not a potency): 73%
Beside the measured number, compound 3's estimate is 28 percentage points below it; the whole stated range lies below it.
By their numbers in this assay, from the lowest: compound 2; then compounds 1 and 3 (each within the scatter of the next).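

With the core unchanged, 3-fluoro-4-methylphenyl in place of 3-chloro-4-methoxyphenyl on a sulfonyl sulfur gives a number 52 percentage points higher from compound 2 to compound 3 (beyond the scatter) in this assay and shows that this aryl change alone can carry a large step. With 3-fluoro-4-methylphenyl held constant, methoxy in place of chloro on an aromatic carbon gives a number 5 percentage points higher from compound 1 to compound 3 (within the scatter) and leaves no separable effect of that change in this pair. No evidence bears on the origin of the large step.

From the compounds shown here alone, whether the step follows the chlorine, the fluorine, the methoxy or the methyl remains open, since both aryl groups differ in two substituents. Going by these compounds, how a nitrile or an amine in place of the methyl of 3-fluoro-4-methylphenyl would read out also remains open.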